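Extending the Acid Chain into a Methyl Amide

The source may hold more compounds than are shown below. What is called first, only, known or untested is meant among the compounds shown, and "the series" means these compounds.

Measured so far in a functional assay for inhibition, with Homo sapiens as the target; a lower number here means a stronger inhibitor, a higher number a weaker inhibitor:
- compound 1 `O=C(O)CCCCCCn1nc(-c2ccccc2)c(-c2ccccc2)c1-c1ccccc1` gives 22400 nM
- compound 2 `CCc1c(-c2ccccc2)nn(CCCCCCCCC(=O)O)c1-c1ccccc1` gives > 79000 nM
- compound 3 `O=C(O)CCCCCCn1cc(-c2ccccc2)c(-c2ccccc2)n1` gives > 92000 nM

Compound 1 holds the only number among these three; the other two readings are limits of this assay. For compound 2 the reading is a limit. For compound 3 the reading is also a limit. Going by the values given here, the single step measured in one place, an at least 4.1-fold higher number from compound 1 to compound 3 (0.61 log units; beyond the scatter), concerns a phenyl group on the core and does not touch the chain. Compound 4 `CNC(=O)CCCCCCCCn1nc(-c2ccccc2)c(-c2ccccc2)c1-c1ccccc1` differs from compound 1 by 2-(methylcarbamoyl)ethyl in place of carboxy on a saturated chain carbon, six bonds along the chain from an aromatic nitrogen. Among the compounds with values here, no measured step bears on this change, so no shift beyond the scatter is foreseen in this assay. The estimate for compound 4 is 30000 nM, between 8000 nM and 120000 nM, an expected step of a 1.3-fold higher number from compound 1 to compound 4 (0.13 log units; within the scatter).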

Compound 4, half-maximal inhibitory concentration: > 68000 nM
Compound 4: a limit, no number (the forecaster's own chance of this, stated with the estimate: 35%); middle value at least 2.2-fold (0.35 log units) from the limit.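

Replacing carboxy with 2-(methylcarbamoyl)ethyl on a saturated chain carbon, six bonds along the chain from an aromatic nitrogen, gives in this assay an at least 3.0-fold higher number from compound 1 to compound 4 (0.48 log units; beyond the scatter). The chain end therefore matters in this assay, which the earlier step on the core could not show. Compound 4 gives a limit, not a number: the limit of > 68000 nM in this assay, at which 1 of the 4 values shown sits.

From the compounds shown here alone, this change lengthens the chain and swaps the acid for a methyl amide at once, so which of the two drives the step stays open. A carboxylic acid on the longer chain of compound 4, with the same core, would separate them.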